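Ethyl for Hydrogen on a Chain Carbon: Expected Response

The source may report more compounds than this note shows. Statements on the series, on what has been measured and on what is new or still open speak of the compounds shown alone.

Two compounds have so far been measured in an assay on CHO cells for agonist activity at Alpha-2B adrenergic receptor (Homo sapiens), with a stated time of 240 min; a lower number here means a smaller maximal response, a higher number a larger maximal response:

Compound 1, `C=CCc1ccccc1NCC1=NCCN1`, gives 0.5 in this assay.
Compound 2, `Cc1ccccc1NCC1=NCCN1`, gives 0.4 in this assay.

Compound 2 stands lowest of the two numbers, with compound 1 its nearest neighbour; the two lie within the scatter of each other, so no order between them can be claimed.

The unmeasured compound 3, `CCCc1ccccc1NCC1=NCCN1`, differs from compound 2 by ethyl in place of hydrogen on a saturated chain carbon bound to an aromatic carbon. Among the measured compounds shown here, the one measured step that touches the same place is a number 0.10 lower from compound 1 to compound 2 (within the scatter), a change at that carbon which did not move the response beyond the scatter. On that basis compound 3 is expected to show no step beyond the scatter in this assay, its estimated step being a number 0.10 higher from compound 2 to compound 3 (within the scatter). Compound 3 is therefore estimated at 0.5, within a range from 0.3 to 0.7.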

Compound 3, intrinsic activity: the largest response reached, as a fraction of the reference agonist's: 0.55
Compound 3: the middle estimate sits 0.050 below what was measured, and the stated range covers the measured number.
By their numbers in this assay, from the lowest: compounds 2, 1 and 3 (each within the scatter of the next, the first and the last beyond it).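

Read in this assay, the change of hydrogen to ethyl on a saturated chain carbon bound to an aromatic carbon gives a number 0.15 higher from compound 2 to compound 3 (beyond the scatter) and is thus the first step at this position to pass beyond the scatter, though only modestly. Ethyl in place of vinyl at the same carbon gives a number 0.050 higher from compound 1 to compound 3 (within the scatter) and so allows no order between these two groups in this assay, which means that the response at this position follows no ordering that separates ethyl from vinyl. No measurement is available that would account for either step.

The compounds shown leave open whether a longer chain, such as butyl, would raise the maximal response further or leave it where ethyl and vinyl stand. They also leave open how a hydroxyl or an amine at this carbon would compare with ethyl.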